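The compounds below may be only part of what the source reports. "The series", "measured", "known", "first", "only" and "open" are said of these compounds alone.

Compound 1, `C[C@@H]1CN(c2cc(NS(=O)(=O)c3ccc(-c4ccccn4)s3)ccc2C#N)C[C@H](C)N1`: 0.9
Compound 2, `COc1ccc(N2C[C@@H](C)N[C@@H](C)C2)cc1NS(=O)(=O)c1ccc(-c2ccccn2)s1`: 1.1

In a functional assay for agonist activity at growth hormone secretagogue receptor type 1 (Homo sapiens), read by FLIPR (on this read-out lower numbers stand for smaller maximal responses and higher numbers for larger maximal responses), compound 2 gives 1.1, the higher of the two values. Compound 1 gives 0.9, a gap that lies beyond the usual scatter. Compound 3, `C[C@@H]1CN(c2ccc(F)c(NS(=O)(=O)c3ccc(-c4ccccn4)s3)c2)C[C@H](C)N1`, has not yet been measured. It differs from compound 2 in one place: fluoro in place of methoxy on an aromatic carbon. Going by the values given here, no measured pair shows this swap, so nothing here fixes its size. A small step is expected, with a modest downward lean or none beyond the scatter, of a number 0.10 lower from compound 2 to compound 3 (within the scatter). Compound 3 is therefore estimated to give about 1, within a range from 0.8 to 1.2.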

Compound 3, intrinsic activity: the largest response reached, as a fraction of the reference agonist's: 0.8
Beside the measured number, compound 3's estimate is 0.20 above it, and the stated range covers the measured number.
By their numbers in this assay, from the lowest: compounds 3 and 1 (each within the scatter of the next); then compound 2.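

In this assay, fluoro in place of methoxy on this aromatic carbon, para to the 3,5-dimethylpiperazin-1-yl group, brings a number 0.30 lower from compound 2 to compound 3 (beyond the scatter). The group on this carbon can therefore shift the maximal response, and a swap of this small size is enough to do so. Nothing available here explains the step. The compounds shown leave open how a hydroxyl, a methyl or an amine on this carbon would read. They also leave open whether ethoxy, a longer chain, would keep the response of compound 2.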